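The source may hold more compounds than are shown below. What is called first, only, known or untested is meant among the compounds shown, and "the series" means these compounds.

Compound 1 `N/C(=N\NC(=S)N1CCCCCC1)c1ccccn1` is the reference of this set. In a functional assay on A-431 cells (Homo sapiens) for cytotoxicity, read by MTT assay, with a stated time of 72 h, tested at 3 uM (on this read-out higher numbers stand for more inhibition of growth at the one concentration tested and lower numbers for less inhibition of growth), compound 1 gives 50.3%, the top number of the three measured, although the gap to compound 3 is within the scatter. Compound 2 `Cc1ccnc(/C(N)=N/NC(=S)N2CCCCCC2)c1` gives 36.1% and compound 3 `Cc1cccc(/C(N)=N/NC(=S)N2CCCCCC2)n1` gives 44.1%. Both carry a methyl in place of hydrogen on an aromatic carbon of the shared core: the step of a number 14.2 percentage points lower from compound 1 to compound 2 (beyond the scatter) lies beyond the scatter, whereas a number 6.2 percentage points lower from compound 1 to compound 3 (within the scatter) stays within it. Compound 4 `N/C(=N\NC(=S)N1CCCCCC1)c1ccc(F)cn1` has not been measured yet. It differs from compound 1 by fluoro in place of hydrogen on an aromatic carbon. Within the data shown here, no measured step adds a fluoro to this ring; the two methyl steps are the only guide, and both pointed downward, by a modest amount or by none beyond the scatter. A step of similar size is therefore expected in this assay, namely a number 6.3 percentage points lower from compound 1 to compound 4 (within the scatter). Compound 4 is estimated at 44%, with an expected range of 26% to 62%.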

Compound 4, percent growth inhibition at one concentration: 62.4%
Compound 4: the middle estimate sits 18.4 percentage points below what was measured; measured number outside the range, above it.
By their numbers in this assay, from the lowest: compounds 2, 3 and 1 (each within the scatter of the next, the first and the last beyond it); then compound 4.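

On the shared core, the ring carbon para to a large group takes fluoro in place of hydrogen with a rise in this assay: a number 12.1 percentage points higher from compound 1 to compound 4 (beyond the scatter). Among these compounds, this is the only upward step in the set, so a substituent on this ring does not always lower the number, as the methyl steps a number 14.2 percentage points lower from compound 1 to compound 2 (beyond the scatter) and a number 6.2 percentage points lower from compound 1 to compound 3 (within the scatter) might have suggested. Nothing available explains the rise.

From the compounds shown here alone, whether it belongs to fluoro itself or to this ring carbon stays open; chloro or methoxy on the same carbon would help separate the two. Going by these compounds, whether the step holds at other concentrations also stays open.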